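Moving the benzyl substituent from chlorine to methyl

The source may report more compounds than this note shows. Statements on the series, on what has been measured and on what is new or still open speak of the compounds shown alone.

The two measured compounds share one core and differ only in the substituted benzyl group attached through the ether oxygen. Compound 1 `Cc1cc(C(=O)O)nn1Cc1cc(Br)ccc1OCc1ccc(Cl)cc1` in a functional assay on CHO-K1 cells for antagonist activity at prostaglandin E2 receptor EP1 subtype (Homo sapiens), read by FLIPR (on this read-out higher numbers stand for weaker inhibition and lower numbers for stronger inhibition), gives 8.71 nM, while compound 2 `Cc1cc(C(=O)O)nn1Cc1cc(Br)ccc1OCc1ccccc1Cl` in this assay gives 28.8 nM. Among the measured compounds shown here, compound 2 thus holds the highest of the two numbers, and the only measured step, a 3.3-fold higher number from compound 1 to compound 2 (0.52 log units; beyond the scatter), separates it from compound 1 by a margin beyond the scatter.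

Compound 3 `Cc1cccc(COc2ccc(Br)cc2Cn2nc(C(=O)O)cc2C)c1` differs from compound 2 by 3-methylphenyl in place of 2-chlorophenyl on a saturated chain carbon bound to an oxygen on an aromatic ring. For the measured compounds named here, no measured step covers a swap of chlorine for methyl, or a move to the 3-position; the single step from compound 1 to compound 2 only shows that where the chlorine sits matters by a modest amount. With nothing closer to lean on, the expectation for compound 3 is a number in the same general region as compound 2, with wide uncertainty, so that a 1.4-fold lower number from compound 2 to compound 3 (0.16 log units; within the scatter) is the estimated step. Compound 3 is therefore estimated at 20 nM in this assay, with a range from 6 nM to 65 nM.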

Compound 3, inhibition constant: 525 nM
Compound 3: middle estimate off by 26-fold (1.42 log units), on the low side, and the stated range ends below it.
By their numbers in this assay, from the lowest: compound 1; then compound 2; then compound 3.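

Placing 3-methylphenyl on the saturated chain carbon bound to an oxygen on an aromatic ring gives an 18-fold higher number from compound 2 to compound 3 (1.26 log units; beyond the scatter) and a 60-fold higher number from compound 1 to compound 3 (1.78 log units; beyond the scatter) in this assay, so this position tolerates some changes far less well than the modest step between the two chlorophenyl groups had shown. Of the three compounds, compound 3 is the weakest inhibitor, even though 3-methylphenyl and 2-chlorophenyl have the same count of heavy atoms, the same six-membered aromatic ring of carbon only, and no hydrogen-bond donors or acceptors, so these counts do not track the loss. Nothing available here accounts for the size of this step.

Compound 3 differs from both chlorinated compounds in the identity of the substituent and in where it sits on the ring, so the compounds shown cannot divide the loss between methyl in place of chlorine and the move to the 3-position. Open too, from the compounds shown here alone, is how 3-chlorophenyl, 2-methylphenyl or 4-methylphenyl would read at this place, and whether a group such as methoxy or an amine on this ring would behave like chlorine or like methyl.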